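The compounds below may be only part of what the source reports. "The series", "measured", "known", "first", "only" and "open" are said of these compounds alone.

Measured so far:
Compound 1 `Cc1ccccc1C(=O)Nc1ncc(-c2ccccc2)n1C`: > 100000 nM
Compound 2 `Cn1c(-c2ccccc2)cnc1NC(=O)c1ccccc1Cl`: > 50000 nM
Compound 3 `Cn1c(-c2ccc(C#N)cc2)cnc1NC(=O)c1ncc[nH]1`: > 100000 nM

All three compounds were tested in a toxicity assay on THP-1 cells (Homo sapiens) for inhibition (on this read-out higher numbers stand for lower toxicity in this test and lower numbers for higher toxicity in this test), and none of the three results is an exact number. The results sit at two limits: the limit of > 100000 nM in this assay, at which 2 of the 3 values shown sit, and (the limit of > 50000 nM in this assay, at which 1 of the 3 values shown sits). Compound 3 reads > 100000 nM, which is a limit of the assay.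

The untested compound 4 `Cn1c(-c2ccccc2)cnc1NC(=O)c1ncc[nH]1` differs from compound 3 in one place: hydrogen in place of cyano on an aromatic carbon. Hydrogen takes the place of cyano on an aromatic carbon of the six-membered ring, para to a large group.

Within the data shown here, the only measured step is a step that the two limits leave unreadable from compound 1 to compound 2. It concerns a different place in the molecule, and its size cannot be read, so it gives no direct guide to this change. More useful are the two compounds that already lack the cyano group. Compound 1 reads > 100000 nM, which is a limit. Compound 2 reads > 50000 nM, which is also a limit.

With no cyano group, neither compound gave a readable value, so no step beyond the usual scatter is expected in this assay. The expected step is a number no higher from compound 3 to compound 4 (the limit leaves the size open). For compound 4 the estimated value is 100000 nM, with an expected range from 50000 nM to 200000 nM.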

Compound 4, half-maximal cytotoxic concentration: > 100000 nM
Compound 4: a limit, no number (the forecaster's own chance of this, stated with the estimate: 85%); the middle value lies on the limit itself.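

In this assay compound 4 gives > 100000 nM, which is a limit of the assay and not a number. The steps to compound 4 from compound 1, compound 2 and compound 3 therefore cannot be read. The compounds shown leave open whether hydrogen in place of cyano, or any other change here, alters toxicity in these cells at all.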